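An ethyl in place of a methyl on the shared core

The source may report more compounds than this note shows. Statements on the series, on what has been measured and on what is new or still open speak of the compounds shown alone.

Measured compounds:
compound 1 `Cn1cc(-c2ccc(F)cc2)c(=O)c2c(Nc3ccc(Oc4ccnc(NC(=O)C5CC5)c4)c(F)c3)nccc21` — 24.8%
compound 2 `CCCCC(=O)Nc1cc(Oc2ccc(Nc3nccc4[nH]cc(-c5ccc(F)cc5)c(=O)c34)cc2F)ccn1` — -42.2%

In a functional assay on HT-29 cells (Homo sapiens) for antiproliferative activity, read by MTT assay, with a stated time of 72 h, tested at 10 uM (on this read-out higher numbers stand for more inhibition at the one concentration tested (going by the name of the read-out) and lower numbers for less inhibition), compound 1 gives 24.8%, the higher of the two numbers at hand. Compound 2 gives -42.2% in this assay, a value far below that of compound 1 and beyond the scatter. Within the data shown here, the two compounds differ in more than one place, so no single step can be read from them, and no pair of measured compounds differs by exactly the change at issue here.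

Compound 3 `CCn1cc(-c2ccc(F)cc2)c(=O)c2c(Nc3ccc(Oc4ccnc(NC(=O)C5CC5)c4)c(F)c3)nccc21` differs from compound 1 by methyl in place of hydrogen on a saturated chain carbon bound to an aromatic nitrogen. The change is the smallest possible addition of one carbon, placed on the saturated chain carbon bound to an aromatic nitrogen, away from the parts that differ between compound 1 and compound 2. Among the measured compounds shown here, no measured step supports this, but such a change is expected to leave the read-out close to that of compound 1, with a step of a number 2.2 percentage points higher from compound 1 to compound 3 (within the scatter) that is expected to lie within the scatter. Compound 3 is therefore estimated at 27% in this assay, in a range from 5% to 50%.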

Compound 3, a percentage reported as inhibition, at one concentration (the size of the read-out at that concentration, not a potency): 15.8%
Compound 3: middle estimate off by 11.2 percentage points, on the high side; the range from low to high includes it.
By their numbers in this assay, from the lowest: compound 2; then compounds 3 and 1 (each within the scatter of the next).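

In this assay, among these compounds, the change from methyl to ethyl on the saturated chain carbon bound to an aromatic nitrogen reads a number 9 percentage points lower from compound 1 to compound 3 (within the scatter) and so gives the first single-place step at this position, one that cannot be told apart from the scatter. The pair of compound 1 and compound 2 could not show this, as those two differ in more than one place. Nothing measured on these compounds accounts for the step.

The compounds shown leave open whether a longer chain, or a chain ending in an amine or a carboxylic acid, would also stay within the scatter of compound 1 at this position. Also open, as far as these compounds go, is what a hydrogen in place of the methyl would do on the core of compound 1 with all else kept the same.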